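The source may hold more compounds than are shown below. What is called first, only, known or untested is meant among the compounds shown, and "the series" means these compounds.

Series notes. Compound 3 `O=C(NO)c1ccc(Cc2nnc[nH]2)cc1` holds the lowest number of the three measured in an assay on Sf9 cells for inhibition of protein deacetylase HDAC6 (Homo sapiens), read by fluorescence (a lower number here means a stronger inhibitor, a higher number a weaker inhibitor), where compound 3 gives 198 nM. Compound 2 `NCc1ccc(C(=O)NO)cc1` gives 695 nM in this assay, and compound 1 `Cc1cc(-c2nnc(Sc3ccc(C(=O)NO)c(F)c3)n2C)nn1C` gives 2240 nM. For the measured compounds named here, the only single-point step measured is a 3.5-fold lower number from compound 2 to compound 3 (0.55 log units; beyond the scatter). Compound 4 `O=C(NO)c1ccc(Cc2nnc(-c3ccccc3)[nH]2)cc1` differs from compound 3 by phenyl in place of hydrogen on an aromatic carbon. Going by the values given here, no measured step bears directly on this change; compound 1 carries a different group on its five-membered ring together with other changes, so its value shows only that it runs higher than compound 3. A step of about a 1.7-fold lower number from compound 3 to compound 4 (0.22 log units; within the scatter) is expected, small enough that it may fall within the scatter. Compound 4 is therefore estimated at 120 nM, with a range of 30 nM to 500 nM.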

Compound 4, half-maximal inhibitory concentration: 5 nM
The estimate for compound 4 lay 24-fold (1.38 log units) above the measured number; measured number below the stated range.
By their numbers in this assay, from the lowest: compound 4; then compound 3; then compound 2; then compound 1.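

In this assay phenyl in place of hydrogen on the aromatic carbon of the five-membered ring gives a 40-fold lower number from compound 3 to compound 4 (1.60 log units; beyond the scatter) and is a large step. The earlier compounds shown here gave no clean reading at this position, and this step shows that the carbon two ring bonds from the ring atom that bears a large group strongly affects the number. Nothing at hand accounts for the size of this step. From the compounds shown here alone, it remains open whether a methyl group would give part of the step or whether a pyridyl ring or a methoxy group on the phenyl would keep it.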